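The compounds below may be only part of what the source reports. "The series", "measured", "known", "first", "only" and "open" are said of these compounds alone.

Measured so far:
Compound 1, `O=C/C=C/c1ccccc1OCc1ccccc1`: 6400 nM
Compound 2, `O=C/C=C/c1ccccc1OCc1ccccc1Cl`: 4400 nM

In a functional assay on cells (Neutrophil, Rattus norvegicus, strain Sprague-Dawley) for inhibition (a higher number here means a weaker inhibitor, a lower number a stronger inhibitor), compound 1 gives 6400 nM, which is the highest of the two numbers seen so far. Its nearest neighbour is compound 2, and the step is a 1.5-fold lower number from compound 1 to compound 2 (0.16 log units; within the scatter), so the two values cannot be told apart by this assay. The unmeasured compound 3, `O=C/C=C/c1ccccc1OCc1ccc(Cl)cc1`, differs from compound 1 by chloro in place of hydrogen on an aromatic carbon. Within the data shown here, only one measured step speaks to this change, the one from compound 1 to compound 2, which is the same kind of change, chloro in place of hydrogen on an aromatic carbon, but at a different place; it was a 1.5-fold lower number from compound 1 to compound 2 (0.16 log units; within the scatter), within the scatter. On that single precedent, compound 3 is expected to stay close to compound 1, with a step of a 1.3-fold lower number from compound 1 to compound 3 (0.11 log units; within the scatter) that is not expected to exceed the scatter. The estimate for compound 3 in this assay is therefore 5000 nM, with a range from 2500 nM to 10000 nM.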

Compound 3, half-maximal inhibitory concentration: 7400 nM
Estimate against measurement, compound 3: 1.5-fold (0.17 log units) below; measured number inside the range.
By their numbers in this assay, from the lowest: compounds 2, 1 and 3 (each within the scatter of the next).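

In this assay, chloro in place of hydrogen on an aromatic carbon, para to a large group, gives a 1.2-fold higher number from compound 1 to compound 3 (0.06 log units; within the scatter) and so makes no readable difference at this position. The earlier step, a 1.5-fold lower number from compound 1 to compound 2 (0.16 log units; within the scatter) with chloro at a different place, was also within the scatter, so two placements of this one atom now leave the number indistinguishable from that of the unsubstituted compound. Nothing available explains why the number holds steady at this position.

The compounds shown carry only hydrogen or chloro on this ring, so it remains open whether a larger or very different group at the same carbon, such as a methoxy group, an amine or a carboxylic acid, would move the number beyond the scatter. Also open, as far as these compounds go, is whether changes elsewhere in the shared core would matter more than this one, since all three compounds keep the rest of the structure identical.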